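Acylation of the Ring Nitrogen in a Tetrahydroquinoline Amide Series

This account rests on a few compounds, and the source may have more. Where it says the series, first, only, none or still open, it means among the compounds named here.

Measured so far:
compound 1 `O=C(Nc1ccccc1C(F)(F)F)C1CCc2ccccc2N1` gives 57600 nM;
compound 2 `O=C(Nc1ccccc1O)C1CCc2ccccc2N1` gives 3990 nM;
compound 3 `O=C(Nc1ccccc1)C1CCc2ccccc2N1` gives 72900 nM.

All three values come from a functional assay on ACHN cells (Homo sapiens) for cytotoxicity, read by sulforhodamine B assay, with a stated time of 72 h; a higher number here means a weaker inhibitor of growth, a lower number a stronger inhibitor of growth. Compound 1 stands second highest of the three numbers. Its nearest neighbour is compound 3, reached by a 1.3-fold higher number from compound 1 to compound 3 (0.10 log units; within the scatter); its furthest is compound 2, reached by a 14-fold lower number from compound 1 to compound 2 (1.16 log units; beyond the scatter). Among the measured compounds shown here, the only large step among the measured compounds, an 18-fold higher number from compound 2 to compound 3 (1.26 log units; beyond the scatter), likewise concerns the group on the aromatic carbon of the anilide.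

Compound 4 `O=C(Nc1ccccc1C(F)(F)F)C1CCc2ccccc2N1C(=O)c1ccccc1Cl` is the unmeasured compound. It differs from compound 1 by (2-chlorophenyl)carbonyl in place of hydrogen on a nitrogen on an aromatic ring in a ring. For the measured compounds named here, none of the measured steps touches this nitrogen: every one of them changes the substituent on the aromatic carbon of the anilide, so no measured step bears directly on the change from compound 1 to compound 4. With no guide from the data, the expected step is a 1.3-fold lower number from compound 1 to compound 4 (0.11 log units; within the scatter), that is, no change beyond the scatter, held with wide uncertainty. Compound 4 is therefore estimated at 45000 nM, within a range from 8000 nM to 250000 nM.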

Compound 4, concentration for 50% growth inhibition: 3900 nM
Compound 4: the middle estimate sits 12-fold (1.06 log units) above what was measured, and the stated range ends above it.
By their numbers in this assay, from the lowest: compounds 4 and 2 (each within the scatter of the next); then compounds 1 and 3 (each within the scatter of the next).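

In this assay, the ring nitrogen proves to be a second place where a single change matters: (2-chlorophenyl)carbonyl in place of hydrogen gives a 15-fold lower number from compound 1 to compound 4 (1.17 log units; beyond the scatter). The earlier steps shown here had changed only the substituent on the aromatic carbon of the anilide, so they could not show this. The result also shows that the trifluoromethyl anilide, whose trifluoromethyl group is within the scatter of hydrogen in the step of a 1.3-fold higher number from compound 1 to compound 3 (0.10 log units; within the scatter), can still reach a much lower number through a change at this nitrogen alone. Nothing available accounts for the size of this step.

The compounds shown leave open whether the step depends on the chlorine, the aromatic ring or the carbonyl, which a plain benzoyl or an acetyl group on this nitrogen would separate. They also leave open whether the same acylation lowers the number for the hydroxy anilide, compound 2.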